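The source may report more compounds than this note shows. Statements on the series, on what has been measured and on what is new or still open speak of the compounds shown alone.

Working notes on the series. In a functional assay on a cell-free system (Platelet, plasma, Homo sapiens) for inhibition (on this read-out higher numbers stand for weaker inhibition and lower numbers for stronger inhibition), compound 1 `O=C(O)CCN1Cc2ccc(NC(=O)c3ccc4c(c3)CNCC4)cc2C1=O` gives 1100 nM, while compound 2 `CC(CC(=O)O)N1Cc2ccc(NC(=O)c3ccc4c(c3)CNCC4)cc2C1=O` gives 86 nM. The two differ by hydrogen in place of methyl on a saturated chain carbon bound to an amide-type nitrogen in a ring and a saturated chain carbon, and the step is a 13-fold higher number from compound 2 to compound 1 (1.11 log units; beyond the scatter). Compound 3 `CC(CC(=O)O)N1Cc2ccc(NC(=O)c3cccc(N4CCNCC4)c3)cc2C1=O` carries a different core; how that core differs from the core of compound 2 is not broken down here, and in this assay compound 3 gives 62000 nM, the highest number of the three. Compound 4 `O=C(O)CCN1Cc2ccc(NC(=O)c3cccc(N4CCNCC4)c3)cc2C1=O` is derived from compound 3 by hydrogen in place of methyl on a saturated chain carbon bound to an amide-type nitrogen in a ring and a saturated chain carbon, the same kind of change as between compound 2 and compound 1, made here on the core of compound 3. If this change acts alike on both cores, the step from compound 3 to compound 4 is expected to be a 6.5-fold higher number from compound 3 to compound 4 (0.81 log units; beyond the scatter), resting on compound 2 and compound 1 with a 13-fold higher number from compound 2 to compound 1 (1.11 log units; beyond the scatter). For compound 4 the estimate in this assay is 400000 nM, expected between 100000 nM and 2000000 nM.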

Compound 4, half-maximal inhibitory concentration: 2700 nM
Compound 4: the middle estimate sits 150-fold (2.17 log units) above what was measured; measured number below the stated range.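

In this assay, hydrogen in place of methyl on this saturated chain carbon gives a 23-fold lower number from compound 3 to compound 4 (1.36 log units; beyond the scatter), so the change carries over from the core of compound 2 to the core of compound 3 in neither direction nor size: the same change on two cores in this assay, a 13-fold higher number (1.11 log units; beyond the scatter) from compound 2 to compound 1 and a 23-fold lower number (1.36 log units; beyond the scatter) from compound 3 to compound 4, 290-fold (2.47 log units) apart, beyond the scatter of two such steps

Within these four compounds, the outcome of the change depends on the core that carries it, and one step does not predict the other. The two pairs do not show which part of the cores accounts for the reversal, and they give no rule for any third core.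

From the compounds shown here alone, it stays open whether ethyl on the same saturated chain carbon would follow the step on the core of compound 2 or the step on the core of compound 3. Going by these compounds, how a longer chain in place of 2-carboxyethyl would behave on either core also stays open.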